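The compounds below may be only part of what the source reports. "The series", "measured", "known", "first", "only" and "open" are said of these compounds alone.

Working notes on the series. Compound 2 `N#Cc1cnc(NCc2cnccc2C(F)(F)F)cc1N[C@H]1CC[C@@H](O)CC1` gives 100 nM in an assay on isolated protein for inhibition of protein kinase C theta type (Homo sapiens), read by TR-FRET, with a stated time of 2 h (a lower number here means a stronger inhibitor, a higher number a weaker inhibitor), and carries the lowest number of the three measured compounds. Compound 1 `N#Cc1cnc(NCc2cnccc2C(F)(F)F)cc1NC[C@H]1C[C@@H](O)C1` gives 300 nM in this assay, and compound 3 `N#Cc1cnc(NCc2ccccc2C(F)(F)F)cc1N[C@H]1CC[C@H](O)CC1` gives 4000 nM; compound 3 differs from compound 2 in more than one place, so its value is noted without a step. Compound 4 `N#Cc1cnc(NCc2cnccc2C(F)(F)F)cc1NC[C@H]1CC[C@H](O)CC1` takes ((4-hydroxycyclohexyl)methyl in place of 4-hydroxycyclohexyl on a nitrogen on an aromatic ring). Going by the values given here, the one step that bears on this is a 3.0-fold lower number from compound 1 to compound 2 (0.48 log units; beyond the scatter), where a methylene-linked ring gave way to a ring joined directly to the nitrogen. Reinserting a methylene in compound 4 is therefore expected to give a modest rise in the number, a 2.2-fold higher number from compound 2 to compound 4 (0.34 log units; beyond the scatter). For compound 4 the estimate in this assay is 220 nM, with a range of 80 nM to 700 nM.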

Compound 4, half-maximal inhibitory concentration: 50 nM
Beside the measured number, compound 4's estimate is 4.4-fold (0.64 log units) above it; measured number below the stated range.
By their numbers in this assay, from the lowest: compounds 4 and 2 (each within the scatter of the next); then compound 1; then compound 3.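

On a nitrogen on an aromatic ring, the methylene in (4-hydroxycyclohexyl)methyl leaves compound 4 indistinguishable from compound 2 in this assay: a 2.0-fold lower number from compound 2 to compound 4 (0.30 log units; within the scatter), so a direct link from the ring to this nitrogen is not required. With the methylene held constant, ring identity alone registers in this assay: a 6.0-fold lower number from compound 1 to compound 4 (0.78 log units; beyond the scatter), for 4-hydroxycyclohexyl in place of 3-hydroxycyclobutyl. No measurement available gives a reason for either step. Still open, from the compounds shown here alone, is whether an amine or a carboxylic acid in place of the hydroxyl keeps this level, and whether a longer chain does.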